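Tetrazolylthioacetyl hydrazones: methyl for fluoro, cytotoxicity

The source may hold more compounds than are shown below. What is called first, only, known or untested is meant among the compounds shown, and "the series" means these compounds.

Compound 3 `Cn1nnnc1SCC(=O)N/N=C/c1ccccc1F` is the reference for this step. In an ADME assay on NIH3T3 cells (Mus musculus) for cytotoxicity, read by XTT assay, with a stated time of 24 h (a higher number here means a weaker inhibitor, a lower number a stronger inhibitor), compound 3 gives 2000000 nM. Compound 1 `Cn1nnnc1SCC(=O)N/N=C/c1ccc(Br)cc1` in this assay gives 10000000 nM. Among the two numbers shown, compound 3 holds the lowest, and compound 1, its nearest neighbour, lies beyond the scatter above it. Compound 2 `COc1ccc(/C=N/NC(=O)CSc2nnnn2C)cc1` in this assay gives only a limit, > 10000000 nM. This is the limit of > 10000000 nM in this assay, at which 1 of the 3 values shown sits, and it is not a number. Among the compounds with values here, the one measured step, a number no lower from compound 1 to compound 2 (the limit leaves the size open), a methoxy in place of bromo on an aromatic carbon, ends at that limit, so its size stays open.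

Compound 4 `Cc1ccccc1/C=N/NC(=O)CSc1nnnn1C` is not yet measured. It differs from compound 3 by methyl in place of fluoro on an aromatic carbon, the group entering on an aromatic carbon of a six-membered aromatic ring of carbon only, ortho to a large group. Within the data shown here, no measured step swaps fluoro for methyl, and the single step that is measured has no readable size, so nothing bears directly on this change. For compound 4 the expectation is therefore no step beyond the scatter, a 1.3-fold higher number from compound 3 to compound 4 (0.10 log units; within the scatter), with the range kept wide. Compound 4 is estimated at 2500000 nM in this assay. For compound 4 the expected range runs from 700000 nM to 10000000 nM.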

Compound 4, half-maximal inhibitory concentration: 6320000 nM
The estimate for compound 4 lay 2.5-fold (0.40 log units) below the measured number; measured number inside the range.
By their numbers in this assay, from the lowest: compound 3; then compounds 4 and 1 (each within the scatter of the next).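

Methyl in place of fluoro on an aromatic carbon, ortho to a large group, gives a 3.2-fold higher number from compound 3 to compound 4 (0.50 log units; beyond the scatter) in this assay. Within the data shown here, this is the first readable size, as the earlier step ends at a limit and cannot be read, and it shows that this position is not indifferent to the swap: one heavy atom replaces one heavy atom, with no ring, no hydrogen-bond donor or acceptor and no net charge on either side, yet the number moves beyond the scatter. Nothing measured here gives a reason for this step.

The compounds shown leave open whether the same swap gives a step of similar size at another carbon of the aromatic ring, as this single pair speaks only for the place it occupies. Also open, going by these compounds, is how this position responds to groups of a different kind, such as a hydroxyl, an amine or a carboxylic acid, and whether the direction seen with methyl carries on to a longer chain such as ethyl.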